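Working notes: shifting the hydroxyl from compound 1 to compound 4

This account rests on a few compounds, and the source may have more. Where it says the series, first, only, none or still open, it means among the compounds named here.

Measured compounds and their numbers in an assay on isolated protein for binding affinity to adenosine receptor A1 (Bos taurus); on this read-out lower numbers stand for stronger inhibition and higher numbers for weaker inhibition:
- compound 1, `CC(O)CNc1nc(-c2ccccc2)nc2c1nnn2Cc1ccccc1Cl`: 32000000 nM
- compound 2, `c1ccc(Cn2nnc3c(NC4CC4)nc(-c4ccccc4)nc32)cc1`: 11000000 nM
- compound 3, `CC(O)CNc1nc(-c2ccccc2)nc2c1nnn2Cc1ccccc1F`: 4800000 nM

Compound 1 gives the highest number of the three in this assay. Within the data shown here, its nearest neighbour is compound 2, and its furthest is compound 3; the only step between compounds that differ in one place is a 6.7-fold lower number from compound 1 to compound 3 (0.82 log units; beyond the scatter), which lies beyond the scatter but is modest in size.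

Compound 4, `OCCCNc1nc(-c2ccccc2)nc2c1nnn2Cc1ccccc1Cl`, is not yet measured. It differs from compound 1 by 2-hydroxyethyl in place of 1-hydroxyethyl on a saturated chain carbon bound to a nitrogen on an aromatic ring. The hydroxyl thus moves along the chain while the chain keeps its length, and the chloro-substituted benzyl group is retained. Among the measured compounds shown here, none of the measured steps touches the hydroxyalkyl chain: the one measured step concerns the halogen on the aromatic ring, and compound 2 replaces the whole chain with cyclopropyl. There is therefore no direct guide, and the expectation is for a change in this assay that stays within the scatter or close to it, with no clear direction. Compound 4 is expected at about 25000000 nM, in the range 8000000 nM to 80000000 nM. The step expected from this estimate is a 1.3-fold lower number from compound 1 to compound 4 (0.11 log units; within the scatter).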

Compound 4, inhibition constant: 33000000 nM
Beside the measured number, compound 4's estimate is 1.3-fold (0.12 log units) below it, within the range that was stated.
By their numbers in this assay, from the lowest: compound 3; then compound 2; then compounds 1 and 4 (each within the scatter of the next).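

In this assay the hydroxyalkyl chain on the amino nitrogen now has its first one-place comparison: 2-hydroxypropyl to 3-hydroxypropyl gives a 1.0-fold higher number from compound 1 to compound 4 (0.01 log units; within the scatter) and so leaves the two values within the scatter of each other. With the chloro-substituted benzyl group retained, the position of the hydroxyl on this chain therefore does not separate compound 1 and compound 4 on this read-out, whereas the halogen exchange gives a 6.7-fold lower number from compound 1 to compound 3 (0.82 log units; beyond the scatter) and does reach beyond the scatter. No supporting data bear on why these two chains read alike.

As far as these compounds go, it remains open whether the same hydroxyl shift reads alike with the fluoro group of compound 3. Also open, from the compounds shown here alone, is how this position responds to a longer chain, or to an amine or a carboxylic acid in place of the hydroxyl.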